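The source may hold more compounds than are shown below. What is called first, only, known or untested is meant among the compounds shown, and "the series" means these compounds.

Series notes. Compound 1 `CC(C)(C)OC(=O)N1CCN(C(=O)c2cn(-c3ccc(S(C)(=O)=O)cc3F)nn2)CC1` is the reference point; in an assay on HEK293 cells for agonist activity at Glucose-dependent insulinotropic receptor (Homo sapiens), read by a luciferase reporter, with a stated time of 24 h (a higher number here means that more compound is needed for the effect, a lower number that less compound is needed), compound 1 gives 12.4 nM. Compound 2 `CC(C)(C)OC(=O)N1CCN(C(=O)c2cn(-c3ccc(S(C)(=O)=O)cc3)nn2)CC1` carries the change hydrogen in place of fluoro on an aromatic carbon and in this assay compound 2 gives 3.12 nM, a step of a 4.0-fold lower number from compound 1 to compound 2 (0.60 log units; beyond the scatter). Compound 3 `CC(C)(C)OC(=O)N1CCC(OC(=O)c2cn(-c3ccc(S(C)(=O)=O)cc3F)nn2)CC1` has a different core from compound 1; the difference between the two cores is not broken down here. In this assay compound 3 gives 14 nM, and its value and that of compound 1 lie within the scatter of each other, so nothing separates them. Compound 4 `CC(C)(C)OC(=O)N1CCC(OC(=O)c2cn(-c3ccc(S(C)(=O)=O)cc3)nn2)CC1` is not yet measured and relates to compound 3 as compound 2 does to compound 1, through the change (hydrogen in place of fluoro on an aromatic carbon), which is the same change as before, at the same place. Going by the values given here, the step from compound 3 to compound 4 in this assay is expected to be a 4.0-fold lower number from compound 3 to compound 4 (0.60 log units; beyond the scatter), resting on the single earlier step of a 4.0-fold lower number from compound 1 to compound 2 (0.60 log units; beyond the scatter) and on the two cores behaving alike so far. Compound 4 is therefore estimated at 3.5 nM, between 1.5 nM and 9 nM.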

Compound 4, half-maximal effective concentration: 3.67 nM
For compound 4 the middle estimate is 1.0-fold (0.02 log units) below the measured one; the range from low to high includes it.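

In this assay, hydrogen in place of fluoro on an aromatic carbon gives a 3.8-fold lower number from compound 3 to compound 4 (0.58 log units; beyond the scatter), and this step agrees with the one seen on the core of compound 1: the same change on two cores in this assay, a 4.0-fold lower number (0.60 log units; beyond the scatter) from compound 1 to compound 2 and a 3.8-fold lower number (0.58 log units; beyond the scatter) from compound 3 to compound 4, 1.0-fold (0.02 log units) apart, within the scatter of two such steps. Across these two cores, the change therefore carries over with its size intact, and the choice between them makes no difference to the step that this assay can detect. The finding rests on one matched pair per core and on one change at one place, so it does not extend to other cores or other replacements of fluoro, and it does not explain why the step has this size.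

On these data alone, it remains open how a chloro or methyl group on the same aromatic carbon would compare with fluoro and hydrogen on either core. Also open, as far as these compounds go, is whether the two cores would still run alike if the methylsulfonyl group gave way to a carboxylic acid, or the tert-butyl carbamate to a free amine.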